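Replacing the acetyl group of compound 2

The source may hold more compounds than are shown below. What is called first, only, known or untested is meant among the compounds shown, and "the series" means these compounds.

Values from (an ADME assay on MT4 cells (Homo sapiens) for cytotoxicity, read by MTT assay, with a stated time of 96 h; a higher number here means that more compound is tolerated, a lower number that less compound is tolerated)
- compound 1 (`COc1ccc(-c2nc3cc(/C(C)=N/NC(N)=S)ccc3[nH]2)cc1`) gives (5000 nM)
- compound 2 (`CC(=O)c1ccc2[nH]c(-c3ccoc3)nc2c1`) gives (> 100000 nM) which is a limit

Compound 2 stands only at a limit of the assay (> 100000 nM) and has no number. Compound 3 (`C/C(=N\NC(N)=S)c1ccc2[nH]c(-c3ccoc3)nc2c1`) differs from it by one change (a group of 7 heavy atoms (3 carbon, 3 nitrogen, 1 sulfur; no ring) in place of a group of 3 heavy atoms (2 carbon, 1 oxygen; no ring), on an aromatic carbon) on an aromatic carbon. For the measured compounds named here, no measured step shows this change. The expectation rests on compound 1 (5000 nM) which carries the same entering group. A large expected step (an at least 8.3-fold lower number from compound 2 to compound 3 (0.92 log units; beyond the scatter)) points toward less compound tolerated in this assay here. For compound 3 the estimate is (12000 nM) with an expected range from (3000 nM) to (50000 nM) in this series.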

Compound 3, half-maximal cytotoxic concentration: 86000 nM
For compound 3 the middle estimate is 7.2-fold (0.86 log units) below the measured one, outside the stated range (above it).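

In this assay the change from acetyl at this aromatic carbon reads only as an at least 1.1-fold lower number from compound 2 to compound 3 (0.06 log units; that floor lies within the scatter) and shows no loss of tolerance that can be claimed. With the entering group held, furan-3-yl in place of 4-methoxyphenyl gives a 17-fold higher number from compound 1 to compound 3 (1.24 log units; beyond the scatter) and so that group alone does not set the level. The first step stays a floor because compound 2 is a limit and not a number: the limit of > 100000 nM in this assay, at which 1 of the 3 values shown sits.

Open, from the compounds shown here alone, is whether an amine or a carboxylic acid at this aromatic carbon would keep the level of compound 3. Also open, going by these compounds, is whether leaving acetyl gives a readable step with 4-methoxyphenyl in place of furan-3-yl.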